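The compounds below may be only part of what the source reports. "The series", "measured", "known", "first", "only" and "open" are said of these compounds alone.

Compound 3 `N#Cc1ccc(N2CCN(C(=S)SCc3ccc(C(=O)Nc4ccccc4N)cc3)CC2)cc1` stands highest of the three measured in a functional assay on HeLa cells (Homo sapiens) for antiproliferative activity, read by CCK-8 assay, with a stated time of 72 h, tested at 2 uM (a higher number here means a stronger effect of the compound at the concentration tested, a lower number a weaker effect), where compound 3 gives 71.6%. Compound 2 `Nc1ccccc1NC(=O)c1ccc(CSC(=S)N2CCN(c3ccc(F)cc3)CC2)cc1` gives 60.8% and compound 1 `Nc1ccccc1NC(=O)c1ccc(CSC(=S)N2CCN(c3ccc(Cl)cc3)CC2)cc1` gives 51.2%. Compound 4 `Cc1ccc(N2CCN(C(=S)SCc3ccc(C(=O)Nc4ccccc4N)cc3)CC2)cc1` differs from compound 3 by methyl in place of cyano on an aromatic carbon. For the measured compounds named here, the steps that bear on it are the two onto cyano, a number 20.4 percentage points higher from compound 1 to compound 3 (beyond the scatter) and a number 10.8 percentage points higher from compound 2 to compound 3 (beyond the scatter); the halogen swap a number 9.6 percentage points higher from compound 1 to compound 2 (within the scatter) does not. Going by the values given here, no measured compound carries methyl at this place, so the size of the reverse move is uncertain, but losing cyano is expected to give back a part of what its arrival gained. Compound 4 is estimated at 58%, within 42% to 74%. The expected step is a number 13.6 percentage points lower from compound 3 to compound 4 (beyond the scatter).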

Compound 4, a percentage reported as inhibition, at one concentration (the size of the read-out at that concentration, not a potency): 25.3%
Estimate against measurement, compound 4: 32.7 percentage points above, and the stated range ends above it.
By their numbers in this assay, from the lowest: compound 4; then compounds 1 and 2 (each within the scatter of the next); then compound 3.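

In this assay this position proves more sensitive than the halogens and cyano suggested, since the steps of a number 46.3 percentage points lower from compound 3 to compound 4 (beyond the scatter) and a number 35.5 percentage points lower from compound 2 to compound 4 (beyond the scatter) and a number 25.9 percentage points lower from compound 1 to compound 4 (beyond the scatter) all put methyl below the other three groups. The drop is therefore not confined to the loss of cyano, as methyl also falls short of fluoro and chloro. Nothing available explains this drop. On these data alone, whether methoxy, an amine or a carboxylic acid at this place would sit nearer methyl or nearer cyano stays open.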